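The source may hold more compounds than are shown below. What is called first, only, known or untested is meant among the compounds shown, and "the series" means these compounds.

Compound 3 has the structure `Nc1nc(NCc2ccccc2)c2ncn(/C=C3/CC3(CO)CO)c2n1`. In an ADME assay on BCBL1 cells (Homo sapiens) for cytotoxicity, with a stated time of 7 days (on this read-out higher numbers stand for lower toxicity in this test and lower numbers for higher toxicity in this test), compound 3 gives 19900 nM. That is the only number shown among the three measured compounds; the two other values are limits of the assay rather than numbers. Compound 1, with the structure `CCCCCCCCOc1nc(N)nc2c1ncn2/C=C1/CC1(CO)CO`, gives > 20000 nM in this assay, which is a limit. Compound 2, with the structure `CCCOc1nc(N)nc2c1ncn2/C=C1/CC1(CO)CO`, gives > 20000 nM in this assay, likewise a limit. The steps of a number no higher from compound 1 to compound 3 (the limit leaves the size open) and a number no higher from compound 2 to compound 3 (the limit leaves the size open) are therefore open in size, and the limit of > 20000 nM in this assay, at which 2 of the 3 values shown sit, marks where both starting points sit. The step that the two limits leave unreadable from compound 1 to compound 2 is equally unreadable.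

Compound 4, with the structure `Nc1nc(OCC(F)(F)F)c2ncn(/C=C3/CC3(CO)CO)c2n1`, is the compound still to be measured in this assay. It differs from compound 3 in that (2,2,2-trifluoroethoxy in place of benzylamino on an aromatic carbon). Going by the values given here, the steps that bear on this change are those from compound 1 and compound 2 to compound 3, in which octyloxy or propoxy gives way to benzylamino; both of the oxygen-linked compounds sit at the limit and compound 3 sits just under it, so none of these steps shows a readable size. With an oxygen-linked group returning in compound 4, no movement beyond the scatter is expected, and a report at the limit would be unsurprising. Compound 4 is expected to give 20000 nM, in the range 10000 nM to 40000 nM. The step of a 1.0-fold higher number from compound 3 to compound 4 (0.00 log units; within the scatter) that this estimate means is expected to lie within the scatter.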

Compound 4, half-maximal cytotoxic concentration: > 20000 nM
Compound 4 ended at the assay's limit; the forecaster's own chance of this, stated with the estimate: 70%; the middle value sits exactly at the limit.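

In this assay, replacing benzylamino with 2,2,2-trifluoroethoxy on this aromatic carbon gives a number no lower from compound 3 to compound 4 (the limit leaves the size open), so a group with no ring and a fluorinated chain does not bring the number down from that of compound 3. Compound 4 now joins compound 1 and compound 2 in showing that octyloxy, propoxy and 2,2,2-trifluoroethoxy, three different oxygen-linked groups at this position, all end at the same assay limit, which is a limit and not a number: the limit of > 20000 nM in this assay, at which 3 of the 4 values shown sit. The steps among these three compounds cannot be read, so neither the swap of ethyl or heptyl for trifluoromethyl nor the chain length shows any measurable size here, and compound 3 remains the only compound with a number.

As far as these compounds go, how far compound 1, compound 2 and compound 4 differ from one another beyond the limit stays open, as does whether their true values lie close to that of compound 3. Also open, from the compounds shown here alone, is whether a phenoxy group or a methylamino group on this aromatic carbon would give a number under the limit, and so whether the benzyl ring or the linking nitrogen of compound 3 goes with its readable value.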